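This account rests on a few compounds, and the source may have more. Where it says the series, first, only, none or still open, it means among the compounds named here.

Working notes on the series. Compound 1 `C/N=C(/NC#N)NCCCn1nc(-c2ccccc2)ccc1=O` gives, in a functional assay on the whole organism with Rattus norvegicus as the target, at a dose of 100 mg/kg (on this read-out lower numbers stand for less inhibition and higher numbers for more inhibition at the one dose given (going by the name of the read-out)), a value of 40.5%. This is the highest of the three numbers in hand, but compound 3 `CC/N=C(/NC#N)NCCCn1nc(C)ccc1=O`, which gives 34.5%, sits within the scatter of it, so no order between these two can be claimed. Compound 2 `O=c1ccc(-c2ccccc2)nn1CCCCNC(=S)NCc1ccccc1` gives 5.4%, well below compound 1 and beyond the scatter. Compound 4 `N/C(S)=N/CCCCn1nc(-c2ccccc2)ccc1=O` has not yet been measured in this assay. It differs from compound 1 by a group of 5 heavy atoms (2 carbon, 2 nitrogen, 1 sulfur; no ring) in place of a group of 7 heavy atoms (3 carbon, 4 nitrogen; no ring), on a saturated chain carbon, three bonds along the chain from an aromatic nitrogen. Within the data shown here, no step between measured compounds matches this change, so its size is not known from the data. Compound 2, whose side chain also carries a sulfur, gives the low number above, and a downward step is therefore expected; compound 4 is estimated at 15%, a range of 0% to 38%, a step of a number 25.5 percentage points lower from compound 1 to compound 4 (beyond the scatter) expected to be beyond the scatter.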

Compound 4, a percentage reported as inhibition, in the whole organism at one dose (the size of the read-out at that dose, not a potency): 72%
Beside the measured number, compound 4's estimate is 57 percentage points below it; measured number above the stated range.
By their numbers in this assay, from the lowest: compound 2; then compounds 3 and 1 (each within the scatter of the next); then compound 4.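

In this assay, the group on a saturated chain carbon, three bonds along the chain from an aromatic nitrogen, clearly matters: a group of 5 heavy atoms (2 carbon, 2 nitrogen, 1 sulfur; no ring) in place of a group of 7 heavy atoms (3 carbon, 4 nitrogen; no ring) gives a number 31.5 percentage points higher from compound 1 to compound 4 (beyond the scatter). A sulfur-bearing group at this place can therefore carry a high number. Nothing in hand explains the step.

Whether the sulfur or the smaller group accounts for it stays open, as the two groups differ in both. On these data alone, how an amine or a carboxylic acid would read at this place is also open.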